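The source may hold more compounds than are shown below. What is called first, only, known or untested is meant among the compounds shown, and "the series" means these compounds.

Working notes on the series.

Compound 1 `COc1cc2cc(Oc3ccc(NC(=O)Nc4cccc(C(F)(F)F)c4)cc3)c(C)nc2cc1OC` and compound 2 `COc1cc2cc(Oc3ccc(NC(=O)Nc4ccc(Cl)c(C(F)(F)F)c4)cc3)c(C)nc2cc1OC` share a core and differ only in the outer aromatic ring. In a functional assay on OVCAR-5 cells (Homo sapiens) for inhibition, read by sulforhodamine B assay, with a stated time of 48 h (on this read-out lower numbers stand for stronger inhibition of growth and higher numbers for weaker inhibition of growth), compound 1 gives 13000 nM; in this assay compound 2 gives 6220 nM. Among the measured compounds shown here, the one measured step, a 2.1-fold lower number from compound 1 to compound 2 (0.32 log units; beyond the scatter), is the chloro entering on an aromatic carbon. On the two numbers to hand, compound 2 stands lowest, with compound 1 the nearest neighbour and its number set apart beyond the scatter.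

Compound 3 `COc1cc2cc(Oc3ccc(NC(=O)Nc4ccc(Cl)c(Cl)c4)cc3)c(C)nc2cc1OC` is not yet measured. It differs from compound 2 by chloro in place of trifluoromethyl on an aromatic carbon. For the measured compounds named here, no measured step exchanges trifluoromethyl for chloro, so nothing on hand bears directly on this change; the only step available, a 2.1-fold lower number from compound 1 to compound 2 (0.32 log units; beyond the scatter), concerns a different position and is modest in size. Absent any direct precedent, a step no larger than the scatter is expected, a 1.0-fold lower number from compound 2 to compound 3 (0.02 log units; within the scatter), in either direction. Compound 3 is therefore estimated at 6000 nM in this assay, within a range from 2500 nM to 15000 nM.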

Compound 3, concentration for total growth inhibition: 34300 nM
For compound 3 the middle estimate is 5.7-fold (0.76 log units) below the measured one; measured number above the stated range.
By their numbers in this assay, from the lowest: compound 2; then compound 1; then compound 3.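

Working notes, continued. In this assay the place held by trifluoromethyl proves sensitive to exchange: chloro in place of trifluoromethyl gives a 5.5-fold higher number from compound 2 to compound 3 (0.74 log units; beyond the scatter), a step beyond the scatter that runs against the earlier chloro step, a 2.1-fold lower number from compound 1 to compound 2 (0.32 log units; beyond the scatter). The 3,4-dichlorophenyl ring also compares unfavourably with the 3-(trifluoromethyl)phenyl ring, with a 2.6-fold higher number from compound 1 to compound 3 (0.42 log units; beyond the scatter), so among these three compounds the lower number on adding chloro is seen only with trifluoromethyl kept in place. No measurement of any property of these groups is available to account for the change.

The compounds shown leave open whether trifluoromethyl is matched by any other group at this place, ortho to a chloro group, such as a nitrile, a methyl or a methoxy group. They also leave open how an amine or a carboxylic acid would fare there, and whether the opposite directions of the two chloro steps would hold on a further pair of compounds.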